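Chain extension on the amine-bound hydroxyalkyl group

The compounds below may be only part of what the source reports. "The series", "measured", "known", "first", "only" and "open" are said of these compounds alone.

Compound 3 `C[C@@H](O)CNC(C)(C)C(=O)N[C@@H]1CCc2ccccc2N(Cc2ccc(-c3ccccc3-c3nn[nH]n3)cc2)C1=O` gives 300 nM in a functional assay (Pituitary gland cell) with Rattus norvegicus as the target; a lower number here means that less compound is needed, a higher number that more compound is needed for the effect; it stands second highest of the three numbers measured. Compound 1 `CC(C)(O)CNC(C)(C)CC(=O)N[C@@H]1CCc2ccccc2N(Cc2ccc(-c3ccccc3-c3nn[nH]n3)cc2)C1=O` gives 10 nM and compound 2 `CC(C)[C@H](O)CNC(C)(C)CC(=O)N[C@@H]1CCc2ccccc2N(Cc2ccc(-c3ccccc3-c3nn[nH]n3)cc2)C1=O` gives 1000 nM in this assay. Compound 4 `C[C@H](O)CCNC(C)(C)C(=O)N[C@@H]1CCc2ccccc2N(Cc2ccc(-c3ccccc3-c3nn[nH]n3)cc2)C1=O` differs from compound 3 by 2-hydroxypropyl in place of 1-hydroxyethyl on a saturated chain carbon bound to an amine nitrogen.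

The measured steps that bear on this change are those touching the hydroxyalkyl group bound to the amine nitrogen or the chain between the amine and the carbonyl. The step of a 100-fold higher number from compound 1 to compound 2 (2.00 log units; beyond the scatter) is a large loss from a change on the saturated chain carbon bound to the amine nitrogen; the steps of a 30-fold higher number from compound 1 to compound 3 (1.48 log units; beyond the scatter) and a 3.3-fold lower number from compound 2 to compound 3 (0.52 log units; beyond the scatter) alter both the linker and the hydroxyalkyl group at once. Growing the hydroxyalkyl group has so far carried a higher number, so a modest rise is expected from compound 3 to compound 4, a 3.3-fold higher number from compound 3 to compound 4 (0.52 log units; beyond the scatter). Compound 4 is therefore estimated at 1000 nM, within 300 nM to 4000 nM.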

Compound 4, concentration for half-maximal effect: 50 nM
Estimate against measurement, compound 4: 20-fold (1.30 log units) above; the whole stated range lies above it.
By their numbers in this assay, from the lowest: compound 1; then compound 4; then compound 3; then compound 2.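

In this assay, the change from 2-hydroxypropyl to 3-hydroxybutyl on the amine nitrogen gives a 6.0-fold lower number from compound 3 to compound 4 (0.78 log units; beyond the scatter). Growing the hydroxyalkyl group therefore does not always raise the number: this step runs opposite to a 100-fold higher number from compound 1 to compound 2 (2.00 log units; beyond the scatter), the only earlier step confined to that group. The steps of a 20-fold lower number from compound 2 to compound 4 (1.30 log units; beyond the scatter) and a 5.0-fold higher number from compound 1 to compound 4 (0.70 log units; beyond the scatter) alter the linker and the hydroxyalkyl group at once, so neither can be assigned to one change. No evidence accompanies these steps to account for them.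

The linker's contribution alone remains open, as no pair shown differs only there. Also open, from the compounds shown here alone, is whether a longer chain such as 4-hydroxypentyl, or a methoxy group in place of the hydroxyl, would extend the fall seen with 3-hydroxybutyl.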